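The compounds below may be only part of what the source reports. "The series", "measured", "known", "first", "only" and "open" are said of these compounds alone.

Compound 1 `COc1ccc(NC(=O)c2cc(N(C)Cc3ccccc3)ncn2)cc1`: < 5000 nM (a limit)
Compound 2 `CN(Cc1ccccc1)c1cc(C(=O)Nc2ccccc2)ncn1`: < 5000 nM (a limit)
Compound 3 `CCN(Cc1ccc(Cl)cc1)c1cc(C(=O)Nc2ccccc2)ncn1`: 5000 nM

All three results come from a physicochemical assay for solubility, using the shake flask method, measured as kinetic solubility, with a stated time of 2 h, at pH 7.4; on this read-out higher numbers stand for higher solubility and lower numbers for lower solubility. Compound 2 gives only a limit, < 5000 nM, and not an exact number. That is the limit of < 5000 nM in this assay, at which 2 of the 3 values shown sit.

Compound 4 `CN(Cc1ccc(Cl)cc1)c1cc(C(=O)Nc2ccccc2)ncn1` differs from compound 2 by one change: chloro in place of hydrogen on an aromatic carbon. Chloro takes the place of hydrogen on an aromatic carbon, para to a large group, which turns benzyl into 4-chlorobenzyl.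

For the measured compounds named here, the only measured step, a step that the two limits leave unreadable from compound 1 to compound 2, cannot be sized and offers no guide. Going by the values given here, compound 3 also carries 4-chlorobenzyl, and its 5000 nM is the only exact number available, so the expectation rests mainly on that value. No step beyond the usual scatter is expected, and another limit is quite likely. The expected step is a step that the limit leaves unreadable from compound 2 to compound 4.

The estimate for compound 4 is 4000 nM, with an expected range from 2000 nM to 8000 nM.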

Compound 4, solubility: < 5000 nM
Compound 4: a limit, no number; the forecaster's own chance of this, stated with the estimate: 70%; the middle value lies beyond the limit too.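

With chloro in this place, turning benzyl into 4-chlorobenzyl, compound 4 still gives no exact number in this assay, so this change does not lift the shared core to a measurable value. Putting hydrogen in place of methyl on the ethyl chain gives a number no higher from compound 3 to compound 4 (the limit leaves the size open), which suggests that the exact value of compound 3 depends on that chain and not on the chloro alone, while the step involving compound 2 cannot be read at all. Most of the series now sits at one limit, which hides any differences among those compounds: the limit of < 5000 nM in this assay, at which 3 of the 4 values shown sit.

Going by these compounds, how far compound 2 and compound 4 lie past that limit remains open, so the change from hydrogen to chloro has no size. Also open, on these data alone, is what an amine or a carboxylic acid in the same place on this aromatic ring would give.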